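A few compounds are considered here, and "the series" means these few. Any claim that something is new, unique, unknown or untested is made for them only; others in the source may bear on it.

Compound 1, `Cc1ccc(NC(=S)NC(=O)c2ccc(OCc3ccccc3F)cc2)cc1-c1nc2ccccc2[nH]1`, gives 1870 nM in a functional assay on HT-29 cells (Homo sapiens) for inhibition, read by MTT assay, with a stated time of 48 h; a lower number here means a stronger inhibitor, a higher number a weaker inhibitor. Compound 2, `Cc1ccc(NC(=S)NC(=O)c2ccc(OCc3cccc(Cl)c3Cl)cc2)cc1-c1nc2ccccc2[nH]1`, is the outcome of one change to compound 1, (2,3-dichlorophenyl in place of 2-fluorophenyl on a saturated chain carbon bound to an oxygen on an aromatic ring), and in this assay compound 2 gives 63700 nM, so that the step is a 34-fold higher number from compound 1 to compound 2 (1.53 log units; beyond the scatter). Compound 3, `Cc1ccc(NC(=O)NC(=O)c2ccc(OCc3ccccc3F)cc2)cc1-c1nc2ccccc2[nH]1`, carries a different core; the difference between the core of compound 1 and the core of compound 3 is not broken down here. In this assay compound 3 gives 760 nM, the lowest number of the three measured compounds, with compound 1 the nearest to it and compound 2 the furthest. Compound 4, `Cc1ccc(NC(=O)NC(=O)c2ccc(OCc3cccc(Cl)c3Cl)cc2)cc1-c1nc2ccccc2[nH]1`, has not yet been measured. It stands to compound 3 as compound 2 stands to compound 1, the change being (2,3-dichlorophenyl in place of 2-fluorophenyl on a saturated chain carbon bound to an oxygen on an aromatic ring), at the same place in both pairs. Because the same change gave a 34-fold higher number from compound 1 to compound 2 (1.53 log units; beyond the scatter), a step of about the same size is expected from compound 3 to compound 4, namely a 29-fold higher number from compound 3 to compound 4 (1.46 log units; beyond the scatter). Compound 4 is therefore estimated at 22000 nM in this assay, with a likely range from 5000 nM to 90000 nM.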

Compound 4, half-maximal inhibitory concentration: 48500 nM
The estimate for compound 4 lay 2.2-fold (0.34 log units) below the measured number; the measured number falls inside the stated range.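

In this assay, putting 2,3-dichlorophenyl in place of 2-fluorophenyl on the second core gave a 64-fold higher number from compound 3 to compound 4 (1.80 log units; beyond the scatter), so the number rose on this core as well. The two steps point the same way and do not differ in size beyond what repeated measurements would scatter, so the change carried over between these two cores: the same change on two cores in this assay, a 34-fold higher number (1.53 log units; beyond the scatter) from compound 1 to compound 2 and a 64-fold higher number (1.80 log units; beyond the scatter) from compound 3 to compound 4, 1.9-fold (0.27 log units) apart, within the scatter of two such steps This rests on a single pair of cores in a single assay; it does not show that the change would behave alike on any other core, and it does not separate the loss of the fluorine from the gain of the two chlorines.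

The compounds shown leave open how a plain phenyl, a monochlorophenyl or a methoxyphenyl would behave at this place on either core. They also leave open whether a step of this size would persist with a longer chain between the oxygen and the ring, or in any cell line other than the one used in this assay.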